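The source may hold more compounds than are shown below. What is called first, only, known or untested is meant among the compounds shown, and "the series" means these compounds.

Measured in a functional assay on HCT-116 cells (Homo sapiens) for inhibition, read by CCK-8 assay, with a stated time of 72 h, tested at 2 uM; on this read-out higher numbers stand for more inhibition of growth at the one concentration tested and lower numbers for less inhibition of growth:
compound 1 `COc1ccc(SCc2ccc(/C=C/C(=O)Nc3ccccc3N)cc2)cc1OC` gives 12.9%
compound 2 `Nc1ccccc1NC(=O)c1ccc(CSc2ccc(Br)cc2)cc1` gives 9.96%
compound 3 `CC(C)(C)c1ccc(SCc2ccc(/C=C/C(=O)Nc3ccccc3N)cc2)cc1` gives 6.66%

All three values lie within the scatter of one another, so compound 2 is not set apart from compound 1 or from compound 3 in this assay. Compound 4 `Nc1ccccc1NC(=O)c1ccc(CSCCc2ccccc2)cc1` is still to be measured; against compound 2 the change is phenethyl in place of 4-bromophenyl on a sulfur. Among the compounds with values here, the only measured step on a group attached to that sulfur is a number 6.2 percentage points lower from compound 1 to compound 3 (within the scatter), made on a different core, and it stays within the scatter. Within the data shown here, nothing measured so far shows a change at this sulfur moving this assay beyond the scatter. The expected step is therefore a number 0 percentage points higher from compound 2 to compound 4 (within the scatter), none beyond the scatter. Compound 4 is estimated at 10%, range 2% to 20%.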

Compound 4, percent growth inhibition at one concentration: 30.5%
Estimate against measurement, compound 4: 20.5 percentage points below; the whole stated range lies below it.
By their numbers in this assay, from the lowest: compounds 3, 2 and 1 (each within the scatter of the next); then compound 4.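

In this assay, within the data shown here, phenethyl in place of 4-bromophenyl on a sulfur gives a number 20.5 percentage points higher from compound 2 to compound 4 (beyond the scatter), the first step at this position to lie beyond the scatter. Both groups carry one six-membered aromatic ring of carbon only and no hydrogen-bond donors or acceptors, so the step arises with those counts unchanged. No available evidence accounts for the step.

Loss of bromine and gain of the chain come together here, and the compounds shown do not separate them. Also open, from the compounds shown here alone, is how a benzyl group or a longer 3-phenylpropyl chain on this sulfur would read.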